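Replacing pyridin-3-yl on the amine nitrogen

The compounds below may be only part of what the source reports. "The series", "measured", "known", "first", "only" and "open" are said of these compounds alone.

Among the compounds with values here, in a functional assay on CWR22R cells (Homo sapiens) for antiproliferative activity, read by CCK-8 assay, with a stated time of 6 days (a lower number here means a stronger inhibitor, a higher number a weaker inhibitor), compound 1 `C[C@@H](Cn1ccc(-c2ccc(C#N)c(Cl)c2)n1)Nc1cccnc1` gives 21600 nM, the highest of the three numbers so far. Compound 2 `C[C@@H](Cn1ccc(-c2ccc(C#N)c(Cl)c2)n1)Nc1ccc2ccccc2c1` gives 4610 nM and compound 3 `C[C@@H](Cn1ccc(-c2ccc(C#N)c(Cl)c2)n1)Nc1ccc2cnccc2c1` gives 2980 nM. These two lie within the scatter of each other, and both lie below compound 1 by more than the scatter. Compound 4 `C[C@@H](Cn1ccc(-c2ccc(C#N)c(Cl)c2)n1)Nc1ncnc2nc[nH]c12` keeps the shared core but changes the group on the amine nitrogen: a group of 9 heavy atoms (5 carbon, 4 nitrogen; one five-membered aromatic ring with 2 hetero atoms, one six-membered aromatic ring with 2 hetero atoms) in place of a group of 6 heavy atoms (5 carbon, 1 nitrogen; one six-membered aromatic ring with 1 hetero atom), on an amine nitrogen. Within the data shown here, no measured pair shows this exact change. However, compound 2 and compound 3 also carry larger groups there than compound 1, so a moderate drop in the number is expected, estimated as a 3.6-fold lower number from compound 1 to compound 4 (0.56 log units; beyond the scatter). For compound 4, the estimated value is 6000 nM, within a range of 1800 nM to 20000 nM.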

Compound 4, half-maximal inhibitory concentration: 4240 nM
Beside the measured number, compound 4's estimate is 1.4-fold (0.15 log units) above it, and the stated range covers the measured number.
By their numbers in this assay, from the lowest: compounds 3, 4 and 2 (each within the scatter of the next); then compound 1.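

In this assay, a group with a five-membered and a six-membered aromatic ring in place of pyridin-3-yl on the amine nitrogen gives a 5.1-fold lower number from compound 1 to compound 4 (0.71 log units; beyond the scatter), so a larger group carrying a hydrogen-bond donor also lowers the number here. Compound 4 stands within the scatter of compound 2 and compound 3, so its added nitrogens and hydrogen-bond donor bring no visible gain over those groups. No measurement shown explains this result.

On these data alone, how a plain phenyl or an acetyl group on the amine nitrogen would compare remains open.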